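The source may hold more compounds than are shown below. What is called first, only, known or untested is meant among the compounds shown, and "the series" means these compounds.

Measured compounds in a physicochemical assay for lipophilicity, at pH 7.4; a lower number here means a more polar compound, a higher number a more lipophilic compound:
Compound 1 `CNS(=O)(=O)c1ccc(-c2cnc(N)c(-c3ccc(OC)nc3)c2)cc1` gives 2.2.
Compound 2 `COc1ccc(-c2cc(-c3ccc(NS(C)(=O)=O)cc3)cnc2N)cn1` gives 2.2.
Compound 3 `COc1ccc(-c2cc(-c3ccc(-n4cncn4)cc3)cnc2N)cn1` gives 2.4.

Compound 3 holds the highest of the three numbers, but its gap to compound 1, a number 0.20 log units higher from compound 1 to compound 3 (within the scatter), and to compound 2, a number 0.20 log units higher from compound 2 to compound 3 (within the scatter), both sit within the scatter, as does no change at the digits printed from compound 1 to compound 2 (within the scatter). None of the three can be set apart from the others on these numbers.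

Compound 4 `COc1ccc(-c2cc(-c3ccc(C(=O)N(C)C)cc3)cnc2N)cn1` is compound 3 with dimethylcarbamoyl in place of 1H-1,2,4-triazol-1-yl on an aromatic carbon. Among the compounds with values here, no measured step exchanges the triazolyl for a dimethylcarbamoyl, so the measured steps bear on it only indirectly: three different groups at this position, methylsulfamoyl, methanesulfonamido and 1H-1,2,4-triazol-1-yl, all land within the scatter of one another. On that basis no step beyond the scatter is expected for compound 4 in either direction. The expected step from compound 3 to compound 4 is a number 0.10 log units lower from compound 3 to compound 4 (within the scatter). Compound 4 is estimated at 2.3, with a range from 1.8 to 2.8. Within the data shown here, the range is set wider than the scatter since none of the measured steps tests a dimethylcarbamoyl at this place.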

Compound 4, distribution coefficient: 2.1
Estimate against measurement, compound 4: 0.20 log units above, within the range that was stated.
By their numbers in this assay, from the lowest: compounds 4, 1, 2 and 3 (each within the scatter of the next).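

In this assay, dimethylcarbamoyl makes a fourth group at this place, on an aromatic carbon para to a large group, and it stays within the scatter of the other three groups (a number 0.30 log units lower from compound 3 to compound 4 (within the scatter); a number 0.10 log units lower from compound 2 to compound 4 (within the scatter); a number 0.10 log units lower from compound 1 to compound 4 (within the scatter)). The exchange at compound 4 is also the first here to remove a five-membered aromatic ring with 3 hydrogen-bond acceptors in favour of a group with no ring and 1 hydrogen-bond acceptor, at 5 heavy atoms on each side, and even this step is not set apart from the scatter. No measured evidence bears on why these numbers fall so close together.

A carboxylic acid, an amine or a longer chain at this place could still give a step beyond the scatter. From the compounds shown here alone, all four compounds share the rest of their structure, so the effect of a change elsewhere on the core stays open.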